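Dropping the methylsulfonyl from the benzimidazole-bearing antagonist

The compounds below may be only part of what the source reports. "The series", "measured", "known", "first", "only" and "open" are said of these compounds alone.

Of the compounds shown here, two sharing one core have been tested. Compound 1 `Cc1nc(C)n(CC(=O)N2CCN(c3sc(C(F)(F)F)nc3-c3nc4c(C(F)(F)F)cccc4[nH]3)C[C@H]2C)n1` carries a trifluoromethyl on its fused bicyclic ring; in a functional assay on Venous blood for antagonist activity at C-X-C chemokine receptor type 3 (Homo sapiens), read by flow cytometry, with a stated time of 30 min, in the presence of a further agent that is not named here (a higher number here means a weaker inhibitor, a lower number a stronger inhibitor), compound 1 gives 747 nM. Compound 2 `Cc1nc(C)n(CC(=O)N2CCN(c3sc(C(F)(F)F)nc3-c3nc4ccc(S(C)(=O)=O)cc4[nH]3)C[C@H]2C)n1` carries a methylsulfonyl there instead; in this assay compound 2 gives 959 nM. The two numbers lie within the scatter of each other, so compound 2 stands alongside compound 1 rather than apart from it.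

Compound 3 `Cc1nc(C)n(CC(=O)N2CCN(c3sc(C(F)(F)F)nc3-c3nc4ccccc4[nH]3)C[C@H]2C)n1` has not yet been measured. It differs from compound 2 in one place: hydrogen in place of methylsulfonyl on an aromatic carbon. For the measured compounds named here, no step between two measured compounds isolates this change, so the expectation rests only on the closeness of compound 1 and compound 2. Compound 3 is expected to give 900 nM in this assay, with a range from 350 nM to 2500 nM. The step of a 1.1-fold lower number from compound 2 to compound 3 (0.03 log units; within the scatter) is expected to stay within the usual scatter, in neither direction beyond it.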

Compound 3, half-maximal inhibitory concentration: 237 nM
Compound 3: middle estimate off by 3.8-fold (0.58 log units), on the high side, and the stated range ends above it.
By their numbers in this assay, from the lowest: compound 3; then compounds 1 and 2 (each within the scatter of the next).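

In this assay this aromatic carbon proves sensitive to substitution: removing methylsulfonyl gives a 4.0-fold lower number from compound 2 to compound 3 (0.61 log units; beyond the scatter) and replacing trifluoromethyl with hydrogen gives a 3.2-fold lower number from compound 1 to compound 3 (0.50 log units; beyond the scatter), both beyond the scatter. The closeness of compound 1 and compound 2 had shown only that these two groups sit level with each other, whereas compound 3 shows that each gives a higher number than the compound carrying hydrogen. Nothing available explains this difference.

Going by these compounds, it remains open whether a single fluorine or a methyl on the same aromatic carbon would stay level with compound 3 or rise towards compound 1 and compound 2. On these data alone, it is also open whether an amine or a hydroxyl there would give a lower number than compound 3.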